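The source may report more compounds than this note shows. Statements on the series, on what has been measured and on what is new or still open speak of the compounds shown alone.

Measured so far:
- compound 1, `CCOC(=O)CCCCOc1ccc2c(=O)c(-c3ccc(O)cc3)coc2c1`: 240 nM
- compound 2, `NCCCCCCOc1ccc2c(=O)c(-c3ccc(O)cc3)coc2c1`: 100 nM
- compound 3, `O=c1c(-c2ccc(O)cc2)coc2cc(OCCCCCCCCCO)ccc12`: 700 nM

In an assay (Cricetulus griseus) for inhibition of aldehyde dehydrogenase, mitochondrial (Homo sapiens) (on this read-out lower numbers stand for stronger inhibition and higher numbers for weaker inhibition), compound 1 stands second highest of the three numbers; its nearest neighbour is compound 2 with a 2.4-fold lower number from compound 1 to compound 2 (0.38 log units; beyond the scatter), and the furthest is compound 3 with a 2.9-fold higher number from compound 1 to compound 3 (0.46 log units; beyond the scatter). The remaining measured step is a 7.0-fold higher number from compound 2 to compound 3 (0.85 log units; beyond the scatter).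

The compound now in question is compound 4, `O=C(O)CCCCCCCCCOc1ccc2c(=O)c(-c3ccc(O)cc3)coc2c1`. Against compound 1 the change is 5-carboxypentyl in place of ethoxycarbonyl on a saturated chain carbon, four bonds along the chain from an oxygen on an aromatic ring.

Within the data shown here, two measured steps bear on this. The step from compound 1 to compound 3 also starts from the ethoxycarbonyl end of compound 1 and also lengthens the chain while ending in a hydrogen-bond donor, and it raised the number modestly. The step from compound 1 to compound 2 is the only case where a terminal group change lowered the number, but that case involved an amino group, which compound 4 does not carry. The chain of compound 4 is closest in length to that of compound 3.

Compound 4 is therefore expected to give a number above that of compound 1, with an estimated step of a 2.5-fold higher number from compound 1 to compound 4 (0.40 log units; beyond the scatter) in this assay. The estimated value for compound 4 is 600 nM, within a range of 250 nM to 1500 nM.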

Compound 4, half-maximal inhibitory concentration: 50 nM
Compound 4: middle estimate off by 12-fold (1.08 log units), on the high side; the whole stated range lies above it.
By their numbers in this assay, from the lowest: compounds 4 and 2 (each within the scatter of the next); then compound 1; then compound 3.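

In this assay, among these compounds, a long chain does not by itself raise the number: with 5-carboxypentyl in place of ethoxycarbonyl there is a 4.8-fold lower number from compound 1 to compound 4 (0.68 log units; beyond the scatter), a change of opposite direction to the one seen with compound 3. What the chain carries at its end therefore matters strongly at this length: carboxy in place of hydroxy gives a 14-fold lower number from compound 3 to compound 4 (1.15 log units; beyond the scatter), the largest step in the set, while the amino-ended and carboxy-ended chains cannot be separated, with a 2.0-fold lower number from compound 2 to compound 4 (0.30 log units; within the scatter). The data at hand offer nothing that explains these differences.

It remains open whether the gain from a terminal carboxylic acid depends on chain length, since the compounds shown include no carboxylic acid on the shorter chain of compound 1 and no amine or ethyl ester on the longer chain of compound 4. With those matched pairs absent, the separate contributions of chain length and terminal group stay unresolved, and it is also unknown how a longer chain ending in a carboxylic acid would read.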